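The source may report more compounds than this note shows. Statements on the series, on what has been measured and on what is new or still open speak of the compounds shown alone.

Measured so far:
- compound 1, `CC(C)C[C@H]1O[C@H](COCc2ccccc2)[C@H](OCc2ccccc2)[C@H](OCc2ccccc2)[C@H]1O`: "not active" (no number reported) in a functional assay on HL-60 cells (Homo sapiens) for antiproliferative activity, read by MTT assay; a higher number here means a weaker inhibitor, a lower number a stronger inhibitor
- compound 2, `CCCC[C@H]1O[C@H](COCc2ccccc2)[C@@H](OCc2ccccc2)[C@H](OCc2ccccc2)[C@H]1O`: "not active" (no number reported)
- compound 3, `O[C@@H]1[C@@H](OCc2ccccc2)[C@H](OCc2ccccc2)[C@@H](COCc2ccccc2)O[C@@H]1CC1CCCCC1`: 17200 nM

Compound 3 stands as the only entry in this assay with a number at all; compounds 1 and 2 give no number, only the report that they are not active. With that single value, compound 3 is the sole reference point for the series.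

Compound 4, `CC(C)C[C@H]1O[C@H](COCc2ccccc2)[C@@H](OCc2ccccc2)[C@H](OCc2ccccc2)[C@H]1O`, is the next step. It differs from compound 3 in one place: isopropyl in place of cyclohexyl on a saturated chain carbon bound to a saturated ring carbon. Within the data shown here, no step between two measured compounds exists in this assay, so the size of this change has to be guessed rather than read off. Among the measured compounds shown here, compound 1, which also bears an isobutyl chain on the core, is not active, and compound 2 with a plain chain is not active either; compound 3 with the cyclohexylmethyl chain is the only one that reaches a number. On that basis compound 4 is expected to lose activity rather than gain it, with a fair chance that this assay reports only a limit.

The estimate for compound 4 in this assay is 45000 nM, with a range from 15000 nM to 150000 nM. This is expected to be a weakening step of a 2.6-fold higher number from compound 3 to compound 4 (0.42 log units; beyond the scatter).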

Compound 4, half-maximal inhibitory concentration: 13900 nM
Beside the measured number, compound 4's estimate is 3.2-fold (0.51 log units) above it; measured number outside the range, below it.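

In this assay the exchange of cyclohexyl for isopropyl on a saturated chain carbon bound to a saturated ring carbon gives a 1.2-fold lower number from compound 3 to compound 4 (0.09 log units; within the scatter) and so shows that the cyclohexyl ring is not required for a numerical result at this place. A measured value is therefore not confined to the cyclohexylmethyl chain, since the isobutyl chain of compound 4 also gives one. Compound 1, with the same isobutyl chain, gives "not active" (no number reported) whereas compound 4 gives 13900 nM and this contrast points to the configuration rather than the chain as the deciding feature for this pair: the fact that compounds 1 and 4 differ only in the configuration as drawn.

Compound 2, with its plain chain, gives "not active" (no number reported) and so the chain is not free of influence, but the shown compounds do not tell which feature of it counts. As far as these compounds go, it remains open whether the configuration has the same weight with the cyclohexylmethyl chain, and how a chain ending in an amine or a carboxylic acid would fare at this place.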